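Moving the amino group on the phenoxy ring of compound 1

The source may report more compounds than this note shows. Statements on the series, on what has been measured and on what is new or still open speak of the compounds shown alone.

Within the data shown here, the three compounds measured so far share one core and differ only in the ring that hangs from the oxygen on the aromatic ring. Compound 1, `CC(Nc1ccccc1Oc1cccc(N)c1)=C1C(=O)CC(c2ccccc2)CC1=O`, has the lowest number of the three in a functional assay on HeLa cells (Homo sapiens) for antiproliferative activity, read by cell counting, with a stated time of 3 days (on this read-out higher numbers stand for weaker inhibition and lower numbers for stronger inhibition), where compound 1 gives 82 nM. Compound 2, `COc1cccc(Oc2ccccc2NC(C)=C2C(=O)CC(c3ccccc3)CC2=O)c1`, gives 93 nM, and compound 3, `CC(=O)c1ccc(Oc2ccccc2NC(C)=C2C(=O)CC(c3ccccc3)CC2=O)cc1`, gives 130 nM. Each of these numbers lies within the scatter of the others, so none of the three can be called stronger or weaker than another.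

The unmeasured compound 4, `CC(Nc1ccccc1Oc1ccc(N)cc1)=C1C(=O)CC(c2ccccc2)CC1=O`, keeps every atom of compound 1 and simply rearranges them: 4-aminophenyl in place of 3-aminophenyl on an oxygen on an aromatic ring.

Among the measured compounds shown here, no measured step moves a group around this ring, so the change has no direct precedent. The steps that do touch this ring all stayed small: a 1.1-fold higher number from compound 1 to compound 2 (0.05 log units; within the scatter), a 1.6-fold higher number from compound 1 to compound 3 (0.20 log units; within the scatter) and a 1.4-fold higher number from compound 2 to compound 3 (0.15 log units; within the scatter). Since every change tried on this ring so far has left the number within the scatter, the expectation for compound 4 in this assay is a step of a 1.2-fold higher number from compound 1 to compound 4 (0.09 log units; within the scatter), in no direction beyond the scatter. Compound 4 is therefore estimated at 100 nM, with a range from 45 nM to 220 nM.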

Compound 4, half-maximal inhibitory concentration: 39 nM
Beside the measured number, compound 4's estimate is 2.6-fold (0.41 log units) above it; measured number below the stated range.
By their numbers in this assay, from the lowest: compound 4; then compounds 1, 2 and 3 (each within the scatter of the next).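

Until now, every change on this ring had stayed within the scatter in this assay, but moving the amino group without gaining or losing an atom gives a 2.1-fold lower number from compound 1 to compound 4 (0.32 log units; beyond the scatter), so the place of the group on the ring matters here and not only its identity. The group also counts when its place is kept, since amino in place of acetyl gives a 3.3-fold lower number from compound 3 to compound 4 (0.52 log units; beyond the scatter), while 4-aminophenyl in place of 3-methoxyphenyl gives a 2.4-fold lower number from compound 2 to compound 4 (0.38 log units; beyond the scatter), which makes compound 4 the most potent of the four in this assay. The data shown offer no measurement that explains why 4-aminophenyl gives the lowest number.

Going by these compounds, it remains open whether a dimethylamino group or a carboxylic acid, taking the place of the amino group of compound 4, would keep this lower number. Among these compounds, only one pair here differs by moving a group around the ring, so it is also open whether such a move would lower the number for any group other than amino.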